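Methyl on the pyrazine ring of compound 3

This account rests on a few compounds, and the source may have more. Where it says the series, first, only, none or still open, it means among the compounds named here.

Compound 3 `NCCOc1cc(NC(=O)c2cnccn2)c2ncccc2c1` carries the aminoethoxy group and an unsubstituted pyrazine. In a functional assay on MIA PaCa-2 cells (Homo sapiens) for inhibition, read by MTT assay, with a stated time of 72 h (a lower number here means a stronger inhibitor, a higher number a weaker inhibitor), compound 3 gives only a limit, > 10000 nM, the point (the limit of > 10000 nM in this assay, at which 1 of the 3 values shown sits). Among the compounds with values here, compound 1 `Cc1cnc(C(=O)Nc2cc(F)cc3cccnc23)cn1` gives 310 nM, and compound 2 `COc1cc(NC(=O)c2cnc(C)cn2)c2ncccc2c1` gives 270 nM; the only step measured within the pair, a 1.1-fold lower number from compound 1 to compound 2 (0.06 log units; within the scatter), concerns a change on the other ring and does not touch the pyrazine. Compound 4 `Cc1cnc(C(=O)Nc2cc(OCCN)cc3cccnc23)cn1` differs from compound 3 by methyl in place of hydrogen on an aromatic carbon. Within the data shown here, no measured step tests this change on its own, since compound 1 and compound 2 both already carry the methyl. With compound 3 sitting at a limit, the expected step of a number no higher from compound 3 to compound 4 (the limit leaves the size open) is undetermined in size, and compound 4 is estimated at 10000 nM, ranging from 2000 nM to 50000 nM, most probably again a limit.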

Compound 4, half-maximal inhibitory concentration: > 10000 nM
Compound 4: a limit, no number (the forecaster's own chance of this, stated with the estimate: 60%); the middle value sits exactly at the limit.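

In this assay, methyl in place of hydrogen on the pyrazine does not bring the aminoethoxy series into a readable range: compound 4 gives > 10000 nM, which is a limit, so the step from compound 3 cannot be read. With the methyl present on both sides, replacing the smaller groups with the aminoethoxy chain gives an at least 37-fold higher number from compound 2 to compound 4 (1.56 log units; beyond the scatter) and an at least 32-fold higher number from compound 1 to compound 4 (1.50 log units; beyond the scatter). Compound 3 and compound 4 both rest at the same limit: the limit of > 10000 nM in this assay, at which 2 of the 4 values shown sit.

From the compounds shown here alone, what the methyl contributes when a value lies off the limit remains open. Also open, going by these compounds, is whether the amine or the chain itself accounts for the large steps, a question that a 2-hydroxyethoxy group in place of 2-aminoethoxy could address.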